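A few compounds are considered here, and "the series" means these few. Any claim that something is new, unique, unknown or untested is made for them only; others in the source may bear on it.

Measured so far in a functional assay on CFPAC-1 cells (Homo sapiens) for antiproliferative activity, read by MTT assay, with a stated time of 72 h; on this read-out lower numbers stand for stronger inhibition and higher numbers for weaker inhibition:
- compound 1, `O=C1O[C@H]([C@@H](O)Cn2cc(CCO)nn2)C(OCc2ccccc2)=C1OCc1ccccc1`: compound 1 sits at the limit > 100000 nM, a limit of the assay and not a number.
- compound 2, `COc1ccccc1-c1cn(C[C@H](O)[C@H]2OC(=O)C(OCc3ccccc3)=C2OCc2ccccc2)nn1`: compound 2 also sits at the limit > 100000 nM, again a limit and not a number.
- compound 3, `CCCCCc1ccc(-c2cn(C[C@H](O)[C@H]3OC(=O)C(OCc4ccccc4)=C3OCc3ccccc3)nn2)cc1`: compound 3 gives 9890 nM.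

Going by the values given here, compound 3 therefore holds the only numerical value; the other two entries are limits. The two readable steps both point the same way: an at least 10-fold lower number from compound 1 to compound 3 (1.00 log units; beyond the scatter) and an at least 10-fold lower number from compound 2 to compound 3 (1.00 log units; beyond the scatter). The step that the two limits leave unreadable from compound 1 to compound 2 cannot be sized, because both of its ends sit at the limit of > 100000 nM in this assay, at which 2 of the 3 values shown sit.

Compound 4, `O=C1O[C@H]([C@@H](O)Cn2cc(CNS(=O)(=O)c3ccc(Cl)cc3)nn2)C(OCc2ccccc2)=C1OCc1ccccc1`, differs from compound 3 as follows: (((4-chlorophenyl)sulfonyl)amino)methyl in place of 4-pentylphenyl on an aromatic carbon. The only measured evidence on this position is that the 4-pentylphenyl group stands out from both 2-hydroxyethyl and 2-methoxyphenyl by at least the sizes given above, and that neither of those two alternatives yields a readable number. Removing the 4-pentylphenyl group is therefore expected to move the value back toward the limit, in the direction of a higher number in this assay, by a step estimated at a 5.1-fold higher number from compound 3 to compound 4 (0.70 log units; beyond the scatter). For compound 4 the expected value in this assay is 50000 nM, within a range from 12000 nM to 200000 nM, with a substantial chance that only a limit is reported.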

Compound 4, half-maximal inhibitory concentration: 38900 nM
The estimate for compound 4 lay 1.3-fold (0.11 log units) above the measured number, within the range that was stated.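

In this assay, the (((4-chlorophenyl)sulfonyl)amino)methyl group gives this position a second readable value, so a number here does not require the 4-pentylphenyl group, nor even an aryl ring bonded directly to the triazole carbon: the aromatic ring in compound 4 sits farther out along a chain holding the sulfonyl and amino units. Against the two earlier entries, the size of the change is only a bound, an at least 2.5-fold lower number from compound 2 to compound 4 (0.41 log units; beyond the scatter) and an at least 2.5-fold lower number from compound 1 to compound 4 (0.41 log units; beyond the scatter), each starting from a limit of the assay and not from a number: the limit of > 100000 nM in this assay, at which 2 of the 4 values shown sit. The 4-pentylphenyl group still gives the lowest number shown, with a 3.9-fold higher number from compound 3 to compound 4 (0.59 log units; beyond the scatter), so the new group recovers part of the effect but does not match it.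

The step from compound 1 to compound 2 remains unreadable, and the compounds shown do not separate the contribution of the pentyl chain from that of its phenyl ring, which a plain phenyl or a 4-heptylphenyl group on the same aromatic carbon would address. Also open, as far as these compounds go, is what the chlorine and the sulfonyl unit each contribute, for which an unsubstituted phenylsulfonyl analogue or a carboxamide linker would be the direct comparison.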